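Replacing 2-(1H-imidazol-1-yl)ethoxy with amino in compound 3

The compounds below may be only part of what the source reports. "The series", "measured", "known", "first", "only" and "open" are said of these compounds alone.

Measured so far in a functional assay for inhibition, with Homo sapiens as the target; on this read-out higher numbers stand for weaker inhibition and lower numbers for stronger inhibition
Compound 1 `Fc1cccc(Nc2nccc(-c3ccccn3)n2)c1` gives 1000 nM
Compound 2 `c1ccc(-c2ccnc(Nc3cccc(OCCn4ccnc4)c3)n2)nc1` gives 400 nM
Still unmeasured: compound 3 `Nc1cccc(Nc2nccc(-c3ccccn3)n2)c1`

Of the two measured compounds, compound 2 stands lowest (400 nM), and so shows the stronger inhibition in this assay. Going by the values given here, only one measured step bears on what follows. It put 2-(1H-imidazol-1-yl)ethoxy in place of fluoro on an aromatic carbon and was modest, though beyond the scatter (a 2.5-fold lower number from compound 1 to compound 2 (0.40 log units; beyond the scatter)). The structure of compound 3 removes that same group (amino in place of 2-(1H-imidazol-1-yl)ethoxy on an aromatic carbon). Among the compounds with values here, no measured compound yet carries amino, so the size of the change remains uncertain. The expectation rests on compound 1 (1000 nM), which also lacks the group, and it reads the measured step in reverse. A modest rise in the number is therefore expected (a 2.0-fold higher number from compound 2 to compound 3 (0.30 log units; within the scatter)), smaller than or close to the measured step. For compound 3 the estimate is (800 nM), with an expected range (250 nM to 2500 nM).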

Compound 3, half-maximal inhibitory concentration: 300 nM
Estimate against measurement, compound 3: 2.7-fold (0.43 log units) above, within the range that was stated.
By their numbers in this assay, from the lowest: compounds 3 and 2 (each within the scatter of the next); then compound 1.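

In this assay, amino in place of 2-(1H-imidazol-1-yl)ethoxy gives a 1.3-fold lower number from compound 2 to compound 3 (0.12 log units; within the scatter) and so leaves the read-out unresolved between the two groups, even though the group that leaves has 8 heavy atoms and a five-membered aromatic ring while amino has 1 heavy atom and no ring. The ring and the chain are therefore not required at this position to reach the level of compound 2, since amino in place of fluoro alone gives a 3.3-fold lower number from compound 1 to compound 3 (0.52 log units; beyond the scatter) in this assay as a modest change that lies beyond the scatter. Among these three compounds, fluoro stands apart from the other two groups, yet no measurement on hand offers an explanation for this.

From the compounds shown here alone, whether the hydrogen-bond donor that amino brings plays any part stays open, and a methoxy or dimethylamino group at this position would bear on that question. Going by these compounds, it also remains open whether a longer chain ending in an amine or a carboxylic acid would move the number beyond the level shared by compound 2 and compound 3.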